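The compounds below may be only part of what the source reports. "The series", "measured", "known", "first", "only" and "open" are said of these compounds alone.

Among the measured compounds shown here, compound 3 `CN(C)CCn1cnnc1-c1cc(Oc2ccc(NC(=O)N/N=C/c3cc(Br)c(O)c(Br)c3)cc2F)ccn1` stands at the far end of the numbers so far. For the measured compounds named here, in a functional assay on A549 cells (Homo sapiens) for cytotoxicity, read by MTT assay, with a stated time of 72 h (a lower number here means a stronger inhibitor, a higher number a weaker inhibitor), compound 3 gives > 100000 nM, which is a limit of the assay rather than a number, the single value resting at the limit of > 100000 nM in this assay, at which 1 of the 3 values shown sits. Compound 1 `CN(C)CCn1cnnc1-c1cc(Oc2ccc(NC(=O)N/N=C/c3ccccc3)cc2F)ccn1` gives 1860 nM in this assay, and compound 2 `CN(C)CCn1cnnc1-c1cc(Oc2ccc(NC(=O)N/N=C/c3ccc(F)cc3F)cc2F)ccn1` gives 1870 nM in this assay; the two differ only by 2,4-difluorophenyl in place of phenyl on a carbon with a double bond to nitrogen, and the step of a 1.0-fold higher number from compound 1 to compound 2 (0.00 log units; within the scatter). Compound 4 `CN(C)CCn1cnnc1-c1cc(Oc2ccc(NC(=O)N/N=C/c3ccc(F)cc3Cl)cc2F)ccn1` has not yet been measured in this assay. It differs from compound 3 by 2-chloro-4-fluorophenyl in place of 3,5-dibromo-4-hydroxyphenyl on a carbon with a double bond to nitrogen. The measured steps that bear on this change are an at least 53-fold higher number from compound 1 to compound 3 (1.73 log units; beyond the scatter) and an at least 53-fold higher number from compound 2 to compound 3 (1.72 log units; beyond the scatter), both large. Compound 4 carries fluorine and chlorine on its phenyl, as compound 2 carries fluorine, and lacks the hydroxyl of compound 3, so the move from compound 3 to compound 4 runs those steps in reverse. Compound 4 is therefore expected to give an estimated 1900 nM, within a range from 700 nM to 6000 nM. That corresponds to an expected step of an at least 52-fold lower number from compound 3 to compound 4 (1.72 log units; beyond the scatter).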

Compound 4, half-maximal inhibitory concentration: 1120 nM
The estimate for compound 4 lay 1.7-fold (0.23 log units) above the measured number, and the stated range covers the measured number.
By their numbers in this assay, from the lowest: compounds 4, 1 and 2 (each within the scatter of the next). At a limit, above all of these: compound 3.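

Placed on a carbon with a double bond to nitrogen, the 2-chloro-4-fluorophenyl group keeps compound 4 in the same range as the earlier compounds in this assay, with a 1.7-fold lower number from compound 2 to compound 4 (0.22 log units; within the scatter) and a 1.7-fold lower number from compound 1 to compound 4 (0.22 log units; within the scatter), so chloro in place of fluoro on an aromatic carbon gives no change beyond the scatter. Halogens on this phenyl therefore do not in themselves bring the large shift seen with compound 3, as an at least 89-fold lower number from compound 3 to compound 4 (1.95 log units; beyond the scatter) shows. That step starts from a limit of the assay, not from a number: the limit of > 100000 nM in this assay, at which 1 of the 4 values shown sits.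

The 3,5-dibromo-4-hydroxyphenyl group of compound 3 carries both bromines and the hydroxyl, and the compounds shown do not separate their contributions. Also open, going by these compounds, is how a phenyl bearing only a hydroxyl, only bromo, or an amine or a carboxylic acid would read here.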